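The compounds below may be only part of what the source reports. "The series", "measured", "known", "first", "only" and "open" are said of these compounds alone.

Compound 1 `CCCCCCc1ccc(NC(=O)N[C@H](C)c2ccccc2)cc1`: 101% in an ADME assay on the whole organism with Oryza sativa as the target, tested at 1 uM; a lower number here means a stronger effect, a higher number a weaker effect of the compound at the concentration tested
Compound 2 `CC(=O)c1ccc(NC(=O)N[C@H](C)c2ccccc2)cc1`: 93%

In this assay compound 2 has the lower of the two numbers, but the step of a number 8 percentage points lower from compound 1 to compound 2 (within the scatter) means the two values cannot be told apart. Compound 3 `C[C@@H](NC(=O)Nc1ccc(Br)cc1)c1ccccc1` differs from compound 2 by bromo in place of acetyl on an aromatic carbon. Within the data shown here, the only measured step bearing on this place, a number 8 percentage points lower from compound 1 to compound 2 (within the scatter), exchanged one group for another there without a change beyond the scatter, so no change beyond the scatter is expected here either. Compound 3 is expected to give 95%, between 80% and 106%. The expected step is a number 2 percentage points higher from compound 2 to compound 3 (within the scatter).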

Compound 3, a percentage reported as activity, at one concentration (the size of the read-out at that concentration, not a potency): 95%
Beside the measured number, compound 3's estimate shows no gap at the digits printed, within the range that was stated.
By their numbers in this assay, from the lowest: compounds 2, 3 and 1 (each within the scatter of the next).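

Swapping acetyl for bromo gives a number 2 percentage points higher from compound 2 to compound 3 (within the scatter) in this assay and swapping hexyl for bromo gives a number 6 percentage points lower from compound 1 to compound 3 (within the scatter) at the same aromatic carbon. A third group at this position therefore joins the first two, and the values for all three cannot be told apart. Nothing measured here accounts for this result. 

On these data alone, whether an amine or a carboxylic acid on this carbon would move the number beyond the scatter remains open. So does whether a change elsewhere on the shared core would do so.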